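Isopropyl in place of chloro: working notes

A few compounds are considered here, and "the series" means these few. Any claim that something is new, unique, unknown or untested is made for them only; others in the source may bear on it.

In a physicochemical assay for lipophilicity, read by HPLC, in phosphate buffer, measured as octanol-water partition, at pH 7.4, tested at 100 uM (on this read-out lower numbers stand for lower lipophilicity and higher numbers for higher lipophilicity), compound 3 `O=C(O)COc1ccc(NCc2cccc(-c3ccccc3Cl)c2)cc1F` gives 2.71 and stands second highest of the three measured numbers, with compound 2 `O=C(O)COc1ccc(NCc2cccc(-c3ccccc3)c2)cc1F` at 2.25 and compound 1 `CCCOc1cc(C)c(-c2cccc(CNc3ccc(OCC(=O)O)c(F)c3)c2)c(C)c1` at 3.59 in the same read-out. Compound 4 `CC(C)c1ccccc1-c1cccc(CNc2ccc(OCC(=O)O)c(F)c2)c1` differs from compound 3 by isopropyl in place of chloro on an aromatic carbon, with isopropyl in place of chloro on an aromatic carbon, ortho to a large group. Within the data shown here, one measured step bears on this change: a number 0.46 log units higher from compound 2 to compound 3 (beyond the scatter), for chloro in place of hydrogen. Among the measured compounds shown here, no measured step isolates isopropyl. A further rise of similar modest size is therefore expected, with an estimated a number 0.49 log units higher from compound 3 to compound 4 (beyond the scatter) in this assay as the working figure. The estimate for compound 4 is 3.2, with an expected range of 2.8 to 3.6 for the measurement.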

Compound 4, distribution coefficient: 3.45
Beside the measured number, compound 4's estimate is 0.25 log units below it; measured number inside the range.
By their numbers in this assay, from the lowest: compound 2; then compound 3; then compounds 4 and 1 (each within the scatter of the next).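

In this assay the rise at this position does not stop at chloro: the change from 2-chlorophenyl to 2-isopropylphenyl gives a number 0.74 log units higher from compound 3 to compound 4 (beyond the scatter), and isopropyl in place of hydrogen gives a number 1.20 log units higher from compound 2 to compound 4 (beyond the scatter). Hydrogen, chloro and isopropyl, ortho to a large group, now stand in one rising order, with no compound shown going against it. Nothing measured here gives a reason for these steps. On these data alone, whether a longer chain at this place would extend the order, or an amine or a carboxylic acid would reverse it, stays open.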